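Trading a Dichlorophenyl Thioether for a Fluorophenoxy Group

This account rests on a few compounds, and the source may have more. Where it says the series, first, only, none or still open, it means among the compounds named here.

Compound 1: `Nc1cc(N)c2nc(-c3ccccc3)c(Oc3ccc(Cl)c(Cl)c3)nc2c1`. In a functional assay on RXF 393 cells (Homo sapiens) for inhibition, read by sulforhodamine B assay, with a stated time of 48 h (on this read-out lower numbers stand for higher toxicity in this test and higher numbers for lower toxicity in this test), compound 1 gives < 100000 nM, which is a limit of the test and not a number.
Compound 2: `Nc1cc(N)c2nc(-c3ccccc3)c(Sc3ccc(Cl)c(Cl)c3)nc2c1`. In this assay compound 2 gives 60300 nM.

Within the data shown here, compound 2 is the only compound with a measured number here; the one other value is a limit. The step that the limit leaves unreadable from compound 1 to compound 2 cannot be sized, since the limit of < 100000 nM in this assay, at which 1 of the 2 values shown sits, hides where compound 1 truly lies. Compound 3, `Nc1cc(N)c2nc(-c3ccccc3)c(Oc3ccc(F)cc3)nc2c1`, is the next compound to be measured. Its change from compound 2 is 4-fluorophenoxy in place of (3,4-dichlorophenyl)sulfanyl on an aromatic carbon. Among the measured compounds shown here, no measured step gives a readable guide to this change: the only comparison on hand is the unreadable one from compound 1, and the two values there show only that both compounds are weakly toxic in this assay. With nothing pointing up or down, compound 3 is expected to sit close to compound 2, with no step beyond the usual scatter, giving an estimated step of a 1.0-fold lower number from compound 2 to compound 3 (0.00 log units; within the scatter). Compound 3 is therefore estimated at 60000 nM in this assay, with a likely range from 20000 nM to 180000 nM, and a fair chance that only a limit is reported.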

Compound 3, concentration lethal to 50% of the cells: < 100000 nM
Compound 3: only a limit was reported; the forecaster's own chance of this, stated with the estimate: 40%; the middle value does not contradict the limit.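

Compound 3 gives only a limit and not a number, so the steps from compound 2 to compound 3 and from compound 1 to compound 3 cannot be read: the limit of < 100000 nM in this assay, at which 2 of the 3 values shown sit.

Going by these compounds, what remains open is how far compound 1 and compound 3 truly lie from compound 2 in this assay, and in which direction.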